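Methyl on Selenium: Compound 3 Set Against Compound 2

A few compounds are considered here, and "the series" means these few. Any claim that something is new, unique, unknown or untested is made for them only; others in the source may bear on it.

Compound 1 `COc1ccc(CNc2nc([SeH])nc3ccccc23)cc1` gives 94000 nM in a functional assay on MCF7 cells (Homo sapiens) for cytotoxicity, read by MTT assay, with a stated time of 72 h; a higher number here means a weaker inhibitor of growth, a lower number a stronger inhibitor of growth.
Compound 2 `CSc1ccc(CNc2nc([SeH])nc3ccccc23)cc1` reaches only the assay limit of > 100000 nM in this assay.

Compound 2 therefore stands at a limit, not a number, in this assay; one of the two values sits at that limit (the limit of > 100000 nM in this assay, at which 1 of the 2 values shown sits). Compound 3 `CSc1ccc(CNc2nc([Se]C)nc3ccccc23)cc1` differs from compound 2 by methyl in place of hydrogen on a selenium. For the measured compounds named here, the only measured step, an at least 1.0-fold higher number from compound 1 to compound 2 (0.02 log units; that floor lies within the scatter), changes a different group and lies within the scatter, so it says little about a change at the selenium. With nothing measured on that group, the step expected from compound 2 to compound 3 is a number no higher from compound 2 to compound 3 (the limit leaves the size open), none beyond the scatter. Compound 3 is estimated at 100000 nM, between 40000 nM and 250000 nM.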

Compound 3, concentration for total growth inhibition: > 100000 nM
Compound 3 gave a limit, no number; the forecaster's own chance of this, stated with the estimate: 55%; the middle value lies on the limit itself.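

No step can be read from compound 2 to compound 3 in this assay, because both stand at a limit rather than a number: the limit of > 100000 nM in this assay, at which 2 of the 3 values shown sit.

The compounds shown leave open what methyl in place of hydrogen on a selenium does to growth inhibition.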